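The compounds below may be only part of what the source reports. "The series", "measured", "known", "first", "only" and "open" are said of these compounds alone.

Measured in a functional assay on the whole organism with Rattus norvegicus as the target; a lower number here means that less compound is needed, a higher number that more compound is needed for the effect:
Compound 1 `CCOC(=O)C(=O)Nc1cccc(OC)c1C#N`: 55.5 mg/kg
Compound 2 `CCOC(=O)C(=O)Nc1ccc(N(C)C)cc1C#N`: 2.4 mg/kg
Compound 3 `CCOC(=O)C(=O)Nc1cc(N(C)C)ccc1C#N`: > 100 mg/kg (a limit of the assay, not a number)

Only two of these three results are actual numbers, and compound 1 holds the higher of them. Compound 2 lies well below it, and that gap is beyond the usual scatter. Compound 3 is known only through its limit, so it cannot be placed exactly.

The next compound to be tested is compound 4 `CCCNc1cccc(NC(=O)C(=O)OCC)c1C#N`, which keeps the core of compound 1 but has propylamino in place of methoxy on an aromatic carbon. The new group sits ortho to a cyano group. Among the compounds with values here, no pair of measured compounds shows this exchange directly, so any expectation remains loose. Compound 2, at 2.4 mg/kg, shows that a member of this series carrying an amino substituent can need far less compound than compound 1. Compound 3 also carries an amino substituent, however, and goes against any simple rule of that kind. A moderate move to a lower number in this assay is therefore expected, estimated as a 4.6-fold lower number from compound 1 to compound 4 (0.67 log units; beyond the scatter). For compound 4 the expected value is 12 mg/kg, with an estimated range from 2 mg/kg to 80 mg/kg.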

Compound 4, dose for half-maximal effect: 0.7 mg/kg
For compound 4 the middle estimate is 17-fold (1.23 log units) above the measured one; the whole stated range lies above it.
By their numbers in this assay, from the lowest: compound 4; then compound 2; then compound 1. At a limit, above all of these: compound 3.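

In this assay, putting propylamino in place of methoxy on the aromatic carbon ortho to a cyano group gives a 79-fold lower number from compound 1 to compound 4 (1.90 log units; beyond the scatter), and this is the first step shown between two compounds that differ in one place. It shows that the requirement for compound in this assay depends strongly on the group at this position, which is meta to a group of 8 heavy atoms, and that propylamino, with 4 heavy atoms and 1 hydrogen-bond donor, is far better here than methoxy, with 2 heavy atoms and 0 hydrogen-bond donors. No measured property among the data shown accounts for the size of this step.

The compounds shown leave open whether the step follows the nitrogen of the new group or the length of its chain, a question on which propoxy or methylamino at this position would bear. They also leave open how far the chain can be extended, as with butylamino, and how a carboxylic acid at the end of the chain would read in this assay.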